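Methyl placement on the five-membered ring: outlook for compound 4

The source may report more compounds than this note shows. Statements on the series, on what has been measured and on what is new or still open speak of the compounds shown alone.

Compound 3 `Cc1n[nH]c(-c2ccccc2NCC2=NCCN2)n1` gives 794 nM in an in vitro functional assay on cells (Fibroblast) for agonist activity at Alpha-1A adrenergic receptor (Homo sapiens) (a lower number here means that less compound is needed, a higher number that more compound is needed for the effect), the highest number of the three measured; compound 1 `c1ccc(-c2nc[nH]n2)c(NCC2=NCCN2)c1` gives 0.794 nM and compound 2 `Cn1ncnc1-c1ccccc1NCC1=NCCN1` gives 2 nM. Both methylated analogues sit above compound 1, but by very different margins: a 2.5-fold higher number from compound 1 to compound 2 (0.40 log units; beyond the scatter) against a 1000-fold higher number from compound 1 to compound 3 (3.00 log units; beyond the scatter), and between the two methyl positions a 400-fold higher number from compound 2 to compound 3 (2.60 log units; beyond the scatter). Compound 4 `Cc1nc(-c2ccccc2NCC2=NCCN2)n(C)n1` carries methyl in place of hydrogen on an aromatic nitrogen. Going by the values given here, the only measured step of the same kind, a 2.5-fold higher number from compound 1 to compound 2 (0.40 log units; beyond the scatter), was modest, so for compound 4 a modest rise at most is expected, with a real chance the step stays within the scatter. Compound 4 is therefore estimated at 1600 nM (range 400 nM to 6000 nM), which means a 2.0-fold higher number from compound 3 to compound 4 (0.30 log units; within the scatter).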

Compound 4, half-maximal effective concentration: 1000 nM
Beside the measured number, compound 4's estimate is 1.6-fold (0.20 log units) above it, and the stated range covers the measured number.
By their numbers in this assay, from the lowest: compound 1; then compound 2; then compounds 3 and 4 (each within the scatter of the next).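

With methyl already on the aromatic carbon, methyl in place of hydrogen on the aromatic nitrogen makes no change beyond the scatter (a 1.3-fold higher number from compound 3 to compound 4 (0.10 log units; within the scatter)). With methyl already on the nitrogen, methyl in place of hydrogen on the aromatic carbon gives a large rise (a 500-fold higher number from compound 2 to compound 4 (2.70 log units; beyond the scatter)), close in size to the same change without the nitrogen methyl (a 1000-fold higher number from compound 1 to compound 3 (3.00 log units; beyond the scatter)). Across these compounds, the large rise goes with the carbon methyl whether the nitrogen carries hydrogen or methyl.

As far as these compounds go, whether an ethyl, an amine or a chlorine on that carbon gives a similar rise stays open. Nothing at hand explains the gap between the two methyl positions.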